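Swapping the amide aryl group on a dopamine receptor agonist scaffold

A few compounds are considered here, and "the series" means these few. Any claim that something is new, unique, unknown or untested is made for them only; others in the source may bear on it.

Measured so far:
- compound 1, `CCc1cccc(NC(=O)CN2CCN(c3ccc(Cl)cn3)CC2)c1`: "not active" (no number reported)
- compound 2, `CCc1cccc(NC(=O)CN2CCN(c3ccccn3)CC2)c1`: 58%
- compound 3, `Cc1ccc(C2CCN(CC(=O)Nc3cccc(C)c3)CC2)nc1`: "not active" (no number reported)

In a functional assay on cells for agonist activity at D(4) dopamine receptor (Homo sapiens), read by TR-FRET and cAMP accumulation, with a stated time of 30 min (a higher number here means a larger maximal response, a lower number a smaller maximal response), compound 1 is recorded as "not active" (no number reported), so no single number stands for it; compound 3 is the second entry of that kind. Among the measured compounds shown here, the one compound with a number is compound 2, which in this assay gives 58%. For the measured compounds named here, compound 2 and compound 1 share the same amide-type nitrogen bearing 3-ethylphenyl, and differ only in the ring attached to the piperazine; no step between them is given, so only the two values themselves can be compared.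

Compound 4, `O=C(CN1CCN(c2ccc(Cl)cn2)CC1)Nc1cccnc1`, keeps the whole of compound 1 apart from one change: pyridin-3-yl in place of 3-ethylphenyl on an amide-type nitrogen. Going by the values given here, no step between measured compounds stands behind this change, and compound 1 itself has no number to move from. With compound 1 reported as "not active" (no number reported) and compound 3 likewise, the expectation in this assay is a small response at best, with a substantial chance that no number is reported at all. The estimate for compound 4 in this assay is 20%, expected to fall between 0% and 55%.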

Compound 4, largest response reached (Emax), in percent of the reference or control that the assay uses: "not active" (no number reported)
For compound 4 the study gives words and no number; the estimate stays without a comparison.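

Compound 1 and compound 4 are both recorded in this assay in words without a number, so no step can be read between them, and no available evidence bears on this result. The compounds shown leave open whether pyridin-3-yl in place of 3-ethylphenyl changes the response at all.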